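Notes on the dimethylcarbamoyl change from compound 2

The compounds below may be only part of what the source reports. "The series", "measured", "known", "first", "only" and "open" are said of these compounds alone.

- compound 1 `CCN(CC)C/C1=C/C[C@](C)(CCC=C(C)C)/C=C/[C@@H](OC(=O)C=C(C)C)[C@](C)(O)/C=C/C1=O` gives 140 nM
- compound 2 `CO/N=C/C1=C/C[C@](C)(CCC=C(C)C)/C=C/[C@@H](OC(=O)C=C(C)C)[C@](C)(O)/C=C/C1=O` gives 4760 nM
- compound 3 `CC(C)=CCC[C@]1(C)/C=C/[C@@H](OC(=O)C=C(C)C)[C@](C)(O)/C=C/C(=O)/C(C(=O)N(C)C)=C\C1` is not yet measured

In a functional assay on HL-60 cells (Homo sapiens) for antiproliferative activity, read by MTT assay, with a stated time of 48 h (on this read-out lower numbers stand for stronger inhibition and higher numbers for weaker inhibition), compound 2 stands at 4760 nM, the higher of the two numbers. Compound 3 changes one group of compound 2: a group of 5 heavy atoms (3 carbon, 1 nitrogen, 1 oxygen; no ring) in place of a group of 4 heavy atoms (2 carbon, 1 nitrogen, 1 oxygen; no ring), on a double-bonded ring carbon. Within the data shown here, the only measured step at this ring carbon is large, a 34-fold higher number from compound 1 to compound 2 (1.53 log units; beyond the scatter), so a change here can move the number far. That single step gives no direct reading for dimethylcarbamoyl, whose count stays close to that of the group it replaces. The expected step is a 1.6-fold lower number from compound 2 to compound 3 (0.20 log units; within the scatter), with no shift beyond the scatter anticipated. The range stays wide in view of a 34-fold higher number from compound 1 to compound 2 (1.53 log units; beyond the scatter). The estimate for compound 3 is 3000 nM, with an expected range from 800 nM to 11000 nM.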

Compound 3, half-maximal inhibitory concentration: 3340 nM
Compound 3: middle estimate off by 1.1-fold (0.05 log units), on the low side, and the stated range covers the measured number.
By their numbers in this assay, from the lowest: compound 1; then compounds 3 and 2 (each within the scatter of the next).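

In this assay, dimethylcarbamoyl and the group it replaces on this double-bonded ring carbon read alike: a 1.4-fold lower number from compound 2 to compound 3 (0.15 log units; within the scatter). Set against (diethylamino)methyl, the same group gives a 24-fold higher number from compound 1 to compound 3 (1.38 log units; beyond the scatter), so the large step now appears twice at this position, both times with (diethylamino)methyl on one side. No supporting data on the origin of this step are available.

From the compounds shown here alone, whether a smaller amine such as dimethylaminomethyl or a cyclic amine such as morpholinomethyl keeps the lower number of compound 1 remains open. Going by these compounds, how a carboxylic acid on this carbon would read is also open.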